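The compounds below may be only part of what the source reports. "The series", "measured", "known", "first", "only" and "open" are said of these compounds alone.

compound 1 `COc1ccc(/C=C(\C#N)C(=O)N/N=C(\C)c2c(O)c3ccc(O)cc3oc2=O)cc1` gives 8940 nM 
compound 2 `C/C(=N\NC(=O)/C(C#N)=C/c1cccc(Br)c1)c1c(O)c2ccc(O)cc2oc1=O` gives 19600 nM 

In a functional assay on MCF7 cells (Homo sapiens) for cytotoxicity, read by MTT assay, with a stated time of 24 h (a higher number here means a weaker inhibitor, a lower number a stronger inhibitor), compound 2 at 19600 nM holds the higher of the two numbers, which makes it the weaker inhibitor of the pair. Its nearest and only neighbour is compound 1 at 8940 nM on the same scale.

The next compound is compound 3 `C/C(=N\NC(=O)/C(C#N)=C/c1ccccc1Cl)c1c(O)c2ccc(O)cc2oc1=O` and it keeps the shared core. It differs from compound 2 only in the aryl group on a double-bonded chain carbon bound to a double-bonded chain carbon, where 2-chlorophenyl stands in place of 3-bromophenyl (2-chlorophenyl in place of 3-bromophenyl on a double-bonded chain carbon bound to a double-bonded chain carbon).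

Within the data shown here, one measured step bears on this place, the move a 2.2-fold higher number from compound 1 to compound 2 (0.34 log units; beyond the scatter) in which 3-bromophenyl replaced 4-methoxyphenyl. That step was modest, though it lay beyond the scatter. Among the measured compounds shown here, it is only indirect evidence, since no measured pair covers the 2-chlorophenyl group, so the direction remains uncertain.

A similarly modest change is expected, leaning slightly toward a stronger inhibitor, and the estimated move is a 1.4-fold lower number from compound 2 to compound 3 (0.15 log units; within the scatter) at most in size. For compound 3 the expected value is 14000 nM with an estimated range from 6000 nM to 32000 nM in this reading.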

Compound 3, half-maximal inhibitory concentration: 8880 nM
For compound 3 the middle estimate is 1.6-fold (0.20 log units) above the measured one; the measured number falls inside the stated range.
By their numbers in this assay, from the lowest: compounds 3 and 1 (each within the scatter of the next); then compound 2.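

In this assay, the aryl group on a double-bonded chain carbon bound to a double-bonded chain carbon now shows a step back down: 2-chlorophenyl in place of 3-bromophenyl gives a 2.2-fold lower number from compound 2 to compound 3 (0.34 log units; beyond the scatter), which leaves compound 2 with the highest number, its steps to both other compounds lying beyond the scatter. The 2-chlorophenyl and 4-methoxyphenyl groups cannot be told apart here, since replacing one with the other gives a 1.0-fold lower number from compound 1 to compound 3 (0.00 log units; within the scatter), so among these three groups only 3-bromophenyl stands apart. Nothing available gives a reason for these differences.

The step from 3-bromophenyl to 2-chlorophenyl changes both the halogen and the place it occupies on the ring, so the compounds shown cannot assign the step to either change, and a 3-chlorophenyl group at this place would separate the two. Also open is how a phenyl group carrying an amine or a carboxylic acid would read in this assay, as all three groups shown carry only a halogen or a methoxy group.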